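The source may report more compounds than this note shows. Statements on the series, on what has been measured and on what is new or still open speak of the compounds shown alone.

Measured in a physicochemical assay for acid dissociation, read by spectrophotometry:
- Compound 1 `Cc1cc(=O)c(O)c(CN2CCCCC2)n1C`: 2.73
- Compound 2 `O=c1cc(CN2CCCCC2)n(CCN2CCCCC2)cc1O`: 2.04

Of these two, compound 2 stands lowest at 2.04, and the gap to compound 1, which gives 2.73, lies beyond the scatter. Compound 3 `Cn1cc(O)c(=O)cc1CN1CCCCC1` departs from compound 2 by a single change: hydrogen in place of (piperidin-1-yl)methyl on a saturated chain carbon bound to an aromatic nitrogen, with hydrogen in place of (piperidin-1-yl)methyl on a saturated chain carbon bound to an aromatic nitrogen. Among the measured compounds shown here, no measured step shows this change, so the expectation is tentative and leans on the value of compound 1, 2.73. A moderate rise is expected, with the estimated step of a number 0.46 log units higher from compound 2 to compound 3 (beyond the scatter). For compound 3 the expected value is 2.5, within an estimated range of 2 to 3.1.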

Compound 3, acid dissociation constant: 2.16
Beside the measured number, compound 3's estimate is 0.34 log units above it; measured number inside the range.
By their numbers in this assay, from the lowest: compounds 2 and 3 (each within the scatter of the next); then compound 1.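

In this assay, hydrogen in place of (piperidin-1-yl)methyl on a saturated chain carbon bound to an aromatic nitrogen gives a number 0.12 log units higher from compound 2 to compound 3 (within the scatter). The two compounds therefore cannot be told apart by this read-out, so this place can lose the whole group, with its six-membered ring, without a resolved difference. The earlier compounds offered no such one-place comparison, and nothing measured here accounts for the result. Going by these compounds, whether a carboxylic acid or a longer chain at this place would leave the number equally unresolved stays open.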